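Solubility notes: aminoalkoxy side chains on the peroxide core

A few compounds are considered here, and "the series" means these few. Any claim that something is new, unique, unknown or untested is made for them only; others in the source may bear on it.

Measured in a physicochemical assay for solubility, read by nephelometry, measured as kinetic solubility, with a stated time of 30 min; a lower number here means a less soluble compound, a higher number a more soluble compound:
- compound 1 `NCCOc1ccc([C@H]2CC[C@]3(CC2)OOC2(O3)C3CC4CC(C3)CC2C4)cc1` gives > 100 ug/mL (a limit of the assay)
- compound 2 `CC(C)(O)CNCCCOc1ccc([C@H]2CC[C@]3(CC2)OOC2(O3)C3CC4CC(C3)CC2C4)cc1` gives > 100 ug/mL (a limit of the assay)
- compound 3 `CC(C)(O)CN1CCC(Oc2ccc([C@H]3CC[C@]4(CC3)OOC3(O4)C4CC5CC(C4)CC3C5)cc2)CC1` gives 1.6 ug/mL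

Compound 1 stands at the upper limit of this assay; its value is a limit, not a number. Compound 2 likewise sits at a limit. the limit of > 100 ug/mL in this assay, at which 2 of the 3 values shown sit, describes where both sit. Compound 4 `CC(C)(CN)Oc1ccc([C@H]2CC[C@]3(CC2)OOC2(O3)C3CC4CC(C3)CC2C4)cc1` has not been measured. The change is 1-(aminomethyl)-1-methylethyl in place of 2-aminoethyl on an oxygen on an aromatic ring. Among the measured compounds shown here, two measured steps bear on it. The step that the two limits leave unreadable from compound 1 to compound 2 is unreadable, both ends being limits. The step of an at least 62-fold lower number from compound 1 to compound 3 (1.79 log units; beyond the scatter) is large, but it brings in a piperidine ring and moves the nitrogen into that ring; the step of an at least 62-fold lower number from compound 2 to compound 3 (1.79 log units; beyond the scatter) is the same size. Compound 4 keeps an open chain with a primary amine, closer to compound 1 and compound 2 than to compound 3, so no step beyond the scatter is expected. The estimated step is a number no higher from compound 1 to compound 4 (the limit leaves the size open). Compound 4 is therefore expected at 100 ug/mL, ranging from 30 ug/mL to 200 ug/mL, most likely reported only as a limit.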

Compound 4, solubility: > 100 ug/mL
Compound 4 was reported as a limit; the forecaster's own chance of this, stated with the estimate: 70%; the middle value lies on the limit itself.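

In this assay compound 4 gives > 100 ug/mL, which is a limit of the assay and not a number. Among the compounds shown here, the steps from compound 1 and from compound 2 to compound 4 cannot be read, both ends being limits, so 1-(aminomethyl)-1-methylethyl on the oxygen on the aromatic ring shows no fall in the reading but gives no size for the change; the one readable step is an at least 62-fold higher number from compound 3 to compound 4 (1.79 log units; beyond the scatter). A third open chain on this oxygen now shares the limit, and compound 3, with its ring, is the only exception: the limit of > 100 ug/mL in this assay, at which 3 of the 4 values shown sit.

Any order among compound 1, compound 2 and compound 4 stays hidden by the limit. Also open, as far as these compounds go, is how a plain piperidin-4-yl on the same oxygen, without 2-hydroxy-2-methylpropyl on its nitrogen, or a carboxylic acid in place of the amine, would read.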